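The compounds below may be only part of what the source reports. "The series", "measured", "known", "first", "only" and "open" are said of these compounds alone.

Three compounds have been measured in a functional assay on NCI-H322 cells (Homo sapiens) for cytotoxicity, read by MTT assay, with a stated time of 24 h; a lower number here means a stronger inhibitor, a higher number a weaker inhibitor:

Compound 1 `COc1cccc(-n2cc(COc3c(/C=C\C(=O)O)ccc(OC)c3CC=C(C)C)nn2)c1`: 25200 nM
Compound 2 `COc1ccc(/C=C\C(=O)O)c(OCc2cn(-c3ccccc3)nn2)c1CC=C(C)C`: 29200 nM
Compound 3 `COc1ccc(/C=C\C(=O)O)c(OCc2cn(-c3ccc(CO)cc3)nn2)c1CC=C(C)C`: 27100 nM

Compound 3 gives the second highest of these three numbers, and all three lie within the scatter of one another: a 1.1-fold higher number from compound 1 to compound 3 (0.03 log units; within the scatter) and a 1.1-fold lower number from compound 2 to compound 3 (0.03 log units; within the scatter). Compound 4 `COc1ccc(/C=C\C(=O)O)c(OCc2cn(-c3nc4ccccc4s3)nn2)c1CC=C(C)C` differs from compound 3 in one place: 1,3-benzothiazol-2-yl in place of 4-(hydroxymethyl)phenyl on an aromatic nitrogen. Among the compounds with values here, two measured steps bear on this change, since both alter the group on that same aromatic nitrogen: a 1.1-fold higher number from compound 1 to compound 3 (0.03 log units; within the scatter) swapped one aryl ring for another, and a 1.1-fold lower number from compound 2 to compound 3 (0.03 log units; within the scatter) added a hydroxymethyl to it. Neither moved the number beyond the scatter, so no step beyond the scatter is expected here either, a 1.0-fold lower number from compound 3 to compound 4 (0.00 log units; within the scatter). Compound 4 is therefore estimated at 27000 nM, with a range of 11000 nM to 65000 nM.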

Compound 4, half-maximal inhibitory concentration: 23000 nM
Compound 4: the middle estimate sits 1.2-fold (0.07 log units) above what was measured, within the range that was stated.
By their numbers in this assay, from the lowest: compounds 4, 1, 3 and 2 (each within the scatter of the next).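

Even a two-ring group fits on this aromatic nitrogen without moving the number beyond the scatter: 1,3-benzothiazol-2-yl, with its five-membered aromatic ring with 2 hetero atoms and 0 hydrogen-bond donors, gives small steps against all three single-ring compounds (a 1.2-fold lower number from compound 3 to compound 4 (0.07 log units; within the scatter); a 1.3-fold lower number from compound 2 to compound 4 (0.10 log units; within the scatter); a 1.1-fold lower number from compound 1 to compound 4 (0.04 log units; within the scatter)). Across these four compounds, then, the choice of aromatic group here has shown no effect beyond the scatter. No supporting measurement is available to explain this. Still open, as far as these compounds go, is whether anything other than an aromatic group on this nitrogen, such as a longer carbon chain or an amine, would shift the number beyond the scatter.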